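This account rests on a few compounds, and the source may have more. Where it says the series, first, only, none or still open, it means among the compounds named here.

Measured so far in an ADME assay on HEK293 cells (Homo sapiens) for cytotoxicity, read by ATP content, with a stated time of 6 h; on this read-out higher numbers stand for lower toxicity in this test and lower numbers for higher toxicity in this test:
- compound 1 `CCCCNc1nc(N)nc2ccn(Cc3ccccn3)c12`: > 24000 nM
- compound 2 `COCCNc1nc(N)nc2ccn(Cc3ccccn3)c12`: > 24000 nM
- compound 3 `Cc1cnc(CNc2nc(N)nc3ccn(Cc4ccccn4)c23)s1`: > 24000 nM

Each of these entries is a limit of the assay and not a number. Compound 3 stands at > 24000 nM, which is a limit. The same holds across the series: the limit of > 24000 nM in this assay, at which 3 of the 3 values shown sit.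

The next compound is compound 4 `Nc1nc(NCc2ccon2)c2c(ccn2Cc2ccccn2)n1`. The change is 1,2-oxazol-3-yl in place of 5-methyl-1,3-thiazol-2-yl on a saturated chain carbon bound to a nitrogen on an aromatic ring. In words, 1,2-oxazol-3-yl takes the place of 5-methyl-1,3-thiazol-2-yl on a saturated chain carbon bound to a nitrogen on an aromatic ring.

Within the data shown here, two measured steps touch this same place: a step that the two limits leave unreadable from compound 1 to compound 3 and a step that the two limits leave unreadable from compound 2 to compound 3. The remaining one is a step that the two limits leave unreadable from compound 1 to compound 2. None of the three has a readable size, so they give no measured effect to carry over. What they do show is that three different groups on this chain all leave this assay at its limit.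

The expectation therefore rests on compound 3 with its limit of > 24000 nM. No step beyond the scatter is expected, and the expected step is a number no higher from compound 3 to compound 4 (the limit leaves the size open). A further limit is the most likely report. For compound 4 the estimated value is 24000 nM, with an expected range of 12000 nM to 40000 nM.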

Compound 4, half-maximal cytotoxic concentration: > 24000 nM
Compound 4 was reported as a limit (the forecaster's own chance of this, stated with the estimate: 85%); the middle value lies on the limit itself.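

In this assay compound 4 gives > 24000 nM, which is a limit. Among these compounds, no step from compound 1, compound 2 or compound 3 to compound 4 can be read. The compounds shown leave open where the true value of any of them lies, and whether any group at this place changes it: the limit of > 24000 nM in this assay, at which 4 of the 4 values shown sit.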